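This account rests on a few compounds, and the source may have more. Where it says the series, first, only, none or still open, it means among the compounds named here.

Compound 1 `CC(C)C(=O)N1CCC(CCCC(=O)c2ncco2)CC1` and compound 2 `Cc1cccc(CN2CCC(CCCC(=O)c3ncco3)CC2)c1` share one core and differ only at the amine nitrogen in a ring. In an assay on isolated protein for inhibition of Fatty-acid amide hydrolase 1 (Homo sapiens) (a lower number here means a stronger inhibitor, a higher number a weaker inhibitor), compound 1 gives 250 nM, and compound 2 gives 90 nM. Within the data shown here, the one measured step, a 2.8-fold lower number from compound 1 to compound 2 (0.44 log units; beyond the scatter), puts 3-methylbenzyl in place of isopropylcarbonyl, and compound 2 so stands with the lower of the two numbers, compound 1 being its only neighbour. Compound 3 `O=C(CCCC1CCN(Cc2ccc(Cl)cc2)CC1)c1ncco1` keeps the benzyl arrangement but alters its aromatic ring: 4-chlorophenyl in place of 3-methylphenyl on a saturated chain carbon bound to an amine nitrogen in a ring. Among the measured compounds shown here, no measured step bears on this exchange of one substituted phenyl for another; the measured step concerns a different kind of group and offers no guide to direction. With nothing to push the expectation either way, compound 3 is expected to land close to compound 2 in this assay, a step of no change at the digits printed from compound 2 to compound 3 (within the scatter) that stays within the usual scatter. The estimate for compound 3 is 90 nM, within a range from 40 nM to 200 nM.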

Compound 3, half-maximal inhibitory concentration: 66 nM
Compound 3: middle estimate off by 1.4-fold (0.13 log units), on the high side; low and high end bracket the measured number.
By their numbers in this assay, from the lowest: compounds 3 and 2 (each within the scatter of the next); then compound 1.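

In this assay, 4-chlorophenyl in place of 3-methylphenyl on a saturated chain carbon bound to an amine nitrogen in a ring gives a 1.4-fold lower number from compound 2 to compound 3 (0.13 log units; within the scatter), so this exchange of one substituted phenyl for another leaves no change that can be told from the scatter. The advantage over the isopropylcarbonyl group of compound 1 is thereby seen with a second benzyl group, as a 3.8-fold lower number from compound 1 to compound 3 (0.58 log units; beyond the scatter) joins a 2.8-fold lower number from compound 1 to compound 2 (0.44 log units; beyond the scatter), and both steps lie beyond the scatter. Nothing is available that explains these numbers.

The step to compound 3 changes the substituent and its place on the ring together, so the compounds shown do not separate the two, as a comparison with 4-methylbenzyl or 3-chlorobenzyl on the same nitrogen could. They also leave open how a plain benzyl, a 4-methoxybenzyl or a simple ethyl group would compare, and so whether the difference from compound 1 rests on the aromatic ring or on the absence of the carbonyl.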